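Morpholine thiosemicarbazide series: swapping the terminal ring

The compounds below may be only part of what the source reports. "The series", "measured", "known", "first", "only" and "open" are said of these compounds alone.

Measured so far:
compound 1 `N/C(=N\NC(=S)N1CCOCC1)c1ccccn1` gives 4800 nM
compound 2 `Cc1ccnc(/C(N)=N/NC(=S)N2CCOCC2)c1` gives 6800 nM
compound 3 `N/C(=N\NC(=S)N1CCOCC1)c1ccc(F)cn1` gives 4000 nM

All three numbers come from a functional assay on A-431 cells (Homo sapiens) for cytotoxicity, read by MTT assay, with a stated time of 72 h; a higher number here means a weaker inhibitor, a lower number a stronger inhibitor. Compound 1 sits between the other two: a 1.2-fold lower number from compound 1 to compound 3 (0.08 log units; within the scatter) and a 1.4-fold higher number from compound 1 to compound 2 (0.15 log units; within the scatter), so the three values are indistinguishable within the usual scatter, and no ordering among them can be read from the data.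

Compound 4 `N/C(=N\NC(=S)N1CCCC1)c1ccccn1` has not yet been measured in this assay. It differs from compound 1 in one place: pyrrolidin-1-yl in place of morpholin-4-yl on a thiocarbonyl carbon.

Neither measured step bears on this change. Going by the values given here, both known steps alter an aromatic carbon of the shared core, whereas the step to compound 4 alters the ring attached to the thiocarbonyl carbon; the data hold no step at that position. Among the compounds with values here, the two measured steps were each small, which says only that the core tolerates small changes elsewhere without a shift beyond the scatter.

Within the data shown here, with no step of the relevant kind in hand, compound 4 is expected to give a number close to that of compound 1, with a wide range to cover the unknown effect of the ring swap; the expected step is a 1.0-fold higher number from compound 1 to compound 4 (0.02 log units; within the scatter). The estimate for compound 4 in this assay is 5000 nM, with a range from 1500 nM to 16000 nM.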

Compound 4, half-maximal inhibitory concentration: 1700 nM
Compound 4: middle estimate off by 2.9-fold (0.47 log units), on the high side; measured number inside the range.
By their numbers in this assay, from the lowest: compound 4; then compounds 3, 1 and 2 (each within the scatter of the next).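

Among the changes shown, the ring on the thiocarbonyl carbon is the only place where a single change moves the number beyond the scatter in this assay: pyrrolidin-1-yl in place of morpholin-4-yl gives a 2.8-fold lower number from compound 1 to compound 4 (0.45 log units; beyond the scatter) as a modest step, while the aromatic-carbon changes give a 1.4-fold higher number from compound 1 to compound 2 (0.15 log units; within the scatter) and a 1.2-fold lower number from compound 1 to compound 3 (0.08 log units; within the scatter) and stay within it. So this position responds to a change of ring, whereas neither change on an aromatic carbon produced a readable shift. The swap replaces a six-membered ring holding an oxygen and a hydrogen-bond acceptor with a five-membered ring holding neither, ring size and oxygen change together in this one step, and no measurement at hand gives a reason for the shift.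

Piperidin-1-yl would keep the six-membered ring without the oxygen, so it would separate those two changes, and an open-chain dimethylamino group would test whether a ring is needed here at all. Also open, going by these compounds, is whether pyrrolidin-1-yl gives a similar step when combined with the methyl or fluoro groups on the shared core.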